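Nitro to cyano swap: growth inhibition notes

A few compounds are considered here, and "the series" means these few. Any claim that something is new, unique, unknown or untested is made for them only; others in the source may bear on it.

Measured in a functional assay on HL-60 cells (Homo sapiens) for inhibition, read by MTT assay, with a stated time of 72 h, tested at 30 uM; a lower number here means less inhibition of growth, a higher number more inhibition of growth at the concentration tested:
- compound 1 `C=CCc1ccc(OCc2cn(-c3cccc([N+](=O)[O-])c3)nn2)c(O)c1`: 29.8%
- compound 2 `C#CCOc1ccc(CC=C)cc1O`: 30.7%

Compound 1 lies within the usual scatter of compound 2, so neither stands apart. Compound 3 `C=CCc1ccc(OCc2cn(-c3cccc(C#N)c3)nn2)c(O)c1` carries cyano in place of nitro on an aromatic carbon, meta to a large group (cyano in place of nitro on an aromatic carbon). Among the compounds with values here, no measured pair tests this change, so no direction can be drawn from the data, and no step beyond the scatter is expected in this assay. The expectation is anchored on compound 1 at 29.8%. The expected step is a number 0.2 percentage points higher from compound 1 to compound 3 (within the scatter). Compound 3 is estimated at 30%, with a range of 14% to 47%.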

Compound 3, percent growth inhibition at one concentration: 22.5%
For compound 3 the middle estimate is 7.5 percentage points above the measured one, within the range that was stated.
By their numbers in this assay, from the lowest: compounds 3, 1 and 2 (each within the scatter of the next).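

Cyano in place of nitro on an aromatic carbon, meta to a large group, gives a number 7.3 percentage points lower from compound 1 to compound 3 (within the scatter) in this assay. The nitro group is therefore not needed at this position for compound 3 to show growth inhibition at the concentration tested, and this single pair gives no sign that the swap matters. No data are at hand that bear on the origin of this result. On these data alone, whether an amine or a carboxylic acid at this position would give a step beyond the scatter remains open. The same holds for a longer chain in place of the allyl-bearing part of the shared core.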